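One Added Methyl, One Cytotoxicity Estimate

The compounds below may be only part of what the source reports. "The series", "measured", "known", "first", "only" and "open" are said of these compounds alone.

In a functional assay on HT-29 cells (Homo sapiens) for cytotoxicity, read by sulforhodamine B assay, with a stated time of 48 h (a higher number here means a weaker inhibitor, a lower number a stronger inhibitor), compound 1 `CCc1ccccc1NS(=O)(=O)c1ccc(NC(=O)NCCCCl)cc1` reaches only a limit, > 200000 nM. Compound 2 `CCCc1ccccc1NS(=O)(=O)c1ccc(NC(=O)NCCCCl)cc1` gives 26000 nM. The change methyl in place of hydrogen on a saturated chain carbon, two bonds along the chain from an aromatic carbon produced an at least 7.6-fold lower number from compound 1 to compound 2 (0.88 log units; beyond the scatter), a size known only as a lower bound because the limit of > 200000 nM in this assay, at which 1 of the 3 values shown sits, is a limit rather than a number. Compound 3 `CCNC(=O)Nc1ccc(S(=O)(=O)Oc2ccccc2CC)cc1` gives 12000 nM, the lowest of the two numbers; how its core differs from the core of compound 1 is not broken down here. Compound 4 `CCCc1ccccc1OS(=O)(=O)c1ccc(NC(=O)NCC)cc1` is not yet measured and differs from compound 3 by methyl in place of hydrogen on a saturated chain carbon, two bonds along the chain from an aromatic carbon, the same change as from compound 1 to compound 2 and its only other occurrence here. The earlier step gives only a floor. For compound 4 a smaller but real gain is expected, estimated as a 3.0-fold lower number from compound 3 to compound 4 (0.48 log units; beyond the scatter). Compound 4 is therefore estimated at 4000 nM, with a range from 1500 nM to 12000 nM.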

Compound 4, half-maximal inhibitory concentration: 2400 nM
For compound 4 the middle estimate is 1.7-fold (0.22 log units) above the measured one, within the range that was stated.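

In this assay, methyl in place of hydrogen on a saturated chain carbon, two bonds along the chain from an aromatic carbon, gave a 5.0-fold lower number from compound 3 to compound 4 (0.70 log units; beyond the scatter). The change lowered the number on both cores, so its direction carried over from one core to the other: the same change on two cores in this assay, an at least 7.6-fold lower number (0.88 log units; beyond the scatter) from compound 1 to compound 2 and a 5.0-fold lower number (0.70 log units; beyond the scatter) from compound 3 to compound 4; the limit leaves it open whether they differ. The value of compound 1 is a limit, so the earlier step is known only as a floor, whether its size carried over stays unshown, and two cores establish no rule for the wider series: the limit of > 200000 nM in this assay, at which 1 of the 4 values shown sits.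

The compounds shown leave open whether a longer chain would lower the number further. They also leave open how an amine or a carboxylic acid in place of the added methyl would read in this assay.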